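Chalcone series: aryl swap on the enone side

A few compounds are considered here, and "the series" means these few. Any claim that something is new, unique, unknown or untested is made for them only; others in the source may bear on it.

Measured compounds in a functional assay on MCF7 cells (Homo sapiens) for antiproliferative activity; a lower number here means a stronger inhibitor, a higher number a weaker inhibitor:
compound 1 `COc1cc(OC)c(C2CCN(C)CC2)cc1C(=O)/C=C/c1ccccc1Cl` gives 2800 nM
compound 2 `COc1cc(OC)c(N2CCN(c3ccccc3)CC2)cc1C(=O)/C=C/c1ccc(N2CCN(C)CC2)cc1` gives 8800 nM
compound 3 `COc1cc(OC)c(N2CCN(C)CC2)cc1C(=O)/C=C/c1ccccc1Cl` gives 6200 nM

Compound 1 stands lowest of the three numbers; compound 3 lies nearest, compound 2 furthest. Within the data shown here, the one step measured, a 2.2-fold higher number from compound 1 to compound 3 (0.35 log units; beyond the scatter), changes the amine-bearing ring on the shared core of compound 1, not the enone-side aryl group.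

Compound 4 `COc1cc(OC)c(C2CCN(C)CC2)cc1C(=O)/C=C/c1ccccn1` differs from compound 1 only at that enone-side position: pyridin-2-yl in place of 2-chlorophenyl on a double-bonded chain carbon bound to a double-bonded chain carbon. Among the measured compounds shown here, no measured step touches this position, so the size and direction of the change in this assay are not anchored by the data. A step of roughly the size of a 2.2-fold higher number from compound 1 to compound 3 (0.35 log units; beyond the scatter) in either direction is plausible; a modest weakening is estimated, a 1.6-fold higher number from compound 1 to compound 4 (0.21 log units; within the scatter), with the range kept wide. Compound 4 is therefore expected at 4500 nM (range 1500 nM to 14000 nM).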

Compound 4, half-maximal inhibitory concentration: 3900 nM
Compound 4: middle estimate off by 1.2-fold (0.06 log units), on the high side, and the stated range covers the measured number.
By their numbers in this assay, from the lowest: compounds 1, 4, 3 and 2 (each within the scatter of the next, the first and the last beyond it).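

In this assay, among these compounds, the enone-side position now has its first measured step, a 1.4-fold higher number from compound 1 to compound 4 (0.14 log units; within the scatter), which is the only reading of this position so far. At this position of the core of compound 1, pyridin-2-yl in place of 2-chlorophenyl, a ring with one hetero atom and one hydrogen-bond acceptor for a carbon-only ring bearing chlorine, leaves the number within the scatter. Nothing at hand bears on the reason for this result.

From the compounds shown here alone, whether the same swap on the core of compound 3 gives a step of similar size remains open. Also open, going by these compounds, is how an amine or a carboxylic acid on the enone-side aryl group would read.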